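The source may report more compounds than this note shows. Statements on the series, on what has been measured and on what is new or still open speak of the compounds shown alone.

Three compounds built on one shared core were tested in an ADME assay on PC-3 cells (Homo sapiens) for cytotoxicity, read by WST assay, tested at 100 uM; on this read-out lower numbers stand for less inhibition and higher numbers for more inhibition at the one concentration tested (going by the name of the read-out). Compound 1 `COC(=O)c1cccc(NC(=O)C2CCCN(C(=O)c3cc(C(F)(F)F)cc(C(F)(F)F)c3)C2)c1` gives 0% in this assay. Compound 2 `O=C(Nc1cccc(Oc2ccccc2)c1)C1CCCN(C(=O)c2cc(C(F)(F)F)cc(C(F)(F)F)c2)C1` gives 1%. Compound 3 `CC(=O)c1cccc(NC(=O)C2CCCN(C(=O)c3cc(C(F)(F)F)cc(C(F)(F)F)c3)C2)c1` gives 0%. Compound 3 thus sits level with compound 1, the two of them together the lowest of the three numbers, and its furthest neighbour is compound 2, with a number 1 percentage points lower from compound 2 to compound 3 (within the scatter). Each exchange among these three stayed small: a number 1 percentage points higher from compound 1 to compound 2 (within the scatter), and no change at the digits printed from compound 1 to compound 3 (within the scatter).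

The next compound, compound 4 `COc1cccc(NC(=O)C2CCCN(C(=O)c3cc(C(F)(F)F)cc(C(F)(F)F)c3)C2)c1`, differs from compound 3 in one place: methoxy in place of acetyl on an aromatic carbon. Of the measured steps, the closest relative is the swap on a carbonyl carbon, no change at the digits printed from compound 1 to compound 3 (within the scatter), which also touches the group sitting meta to a large group on the aromatic ring, and the exchange of that whole group for a phenoxy, a number 1 percentage points higher from compound 1 to compound 2 (within the scatter); both lay within the scatter. On that basis the expected step is a number 1 percentage points higher from compound 3 to compound 4 (within the scatter), with no movement beyond the scatter in either direction. Compound 4 is therefore estimated at 1% in this assay, within a range from 0% to 10%.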

Compound 4, a percentage reported as inhibition, at one concentration (the size of the read-out at that concentration, not a potency): 0%
Estimate against measurement, compound 4: 1 percentage points above, within the range that was stated.
By their numbers in this assay, from the lowest: compounds 1, 3, 4 and 2 (each within the scatter of the next).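

At the ring carbon meta to a large group, the methoxy group now joins acetyl, methoxycarbonyl and phenoxy, and this assay separates none of the four beyond the scatter (no change at the digits printed from compound 3 to compound 4 (within the scatter); no change at the digits printed from compound 1 to compound 4 (within the scatter)). Among these compounds, the new compound also gives the first comparison of two groups attached to the ring through the same oxygen: putting methyl on that oxygen in place of phenyl gives a step that also stays within the scatter (a number 1 percentage points lower from compound 2 to compound 4 (within the scatter)). Across these four compounds, then, neither a carbonyl attached directly to the ring nor the phenyl on the oxygen gives a number that stands apart, and no accompanying measurement offers an explanation for this flat result.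

These compounds leave open whether an amine or a carboxylic acid at the same ring carbon would give a number beyond the scatter of these four. They also leave open what would happen if one of the trifluoromethyl groups of the shared core gave way to a hydrogen or a chlorine atom, since that part stays the same throughout.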